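Trading furan-3-yl for 1H-pyrrol-3-yl on a carbonyl carbon

The source may hold more compounds than are shown below. What is called first, only, known or untested is meant among the compounds shown, and "the series" means these compounds.

Among the measured compounds shown here, in a functional assay on BXPC-3 cells (Homo sapiens) for antiproliferative activity, read by sulforhodamine B assay, with a stated time of 72 h (a lower number here means a stronger inhibitor, a higher number a weaker inhibitor), compound 3 `CC(C)(C)c1[nH]cnc1/C=c1\[nH]c(=O)/c(=C/c2cccc(C(=O)c3ccoc3)c2)[nH]c1=O` gives 9.41 nM, the lowest number measured so far. Compound 2 `CC(C)(C)c1[nH]cnc1/C=c1\[nH]c(=O)/c(=C/c2cccc(C(=O)c3ccncc3)c2)[nH]c1=O` gives 23.8 nM. Compound 1 `CC(C)(C)c1[nH]cnc1/C=c1\[nH]c(=O)/c(=C/c2cccc(C(=O)N3CCC3)c2)[nH]c1=O` reads > 500 nM, which is a limit of the assay. The open question is compound 4 `CC(C)(C)c1[nH]cnc1/C=c1\[nH]c(=O)/c(=C/c2cccc(C(=O)c3cc[nH]c3)c2)[nH]c1=O`, which carries 1H-pyrrol-3-yl in place of furan-3-yl on a carbonyl carbon. For the measured compounds named here, the closest precedent is the modest step of a 2.5-fold lower number from compound 2 to compound 3 (0.40 log units; beyond the scatter), where one aromatic ring replaces another at that place. The large steps of an at least 21-fold lower number from compound 1 to compound 2 (1.32 log units; beyond the scatter) and an at least 53-fold lower number from compound 1 to compound 3 (1.72 log units; beyond the scatter) start from azetidin-1-yl and bear less directly. A small rise is therefore expected, an estimated 1.5-fold higher number from compound 3 to compound 4 (0.17 log units; within the scatter). Compound 4 is estimated at 14 nM, with an expected range of 5 nM to 40 nM.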

Compound 4, half-maximal inhibitory concentration: > 100 nM
Compound 4 gave a limit, no number; the forecaster's own chance of this, stated with the estimate: 5%; middle value at least 7.1-fold (0.85 log units) from the limit.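

In this assay, replacing one five-membered aromatic ring with 1 hetero atom by another on the carbonyl carbon gives an at least 10-fold higher number from compound 3 to compound 4 (1.02 log units; beyond the scatter), so a same-sized aromatic ring does not ensure a low number at this place. 1H-pyrrol-3-yl also falls behind pyridin-4-yl, with an at least 4.2-fold higher number from compound 2 to compound 4 (0.62 log units; beyond the scatter). The reading for compound 4 is a limit and not a number: the limit of > 100 nM in this assay, at which 1 of the 4 values shown sits.

Compound 1 and compound 4 both give limits, so the step between them cannot be read. Going by these compounds, it remains open whether a thiophene ring or a methyl-substituted pyrrole ring on the carbonyl carbon would read like furan-3-yl or like 1H-pyrrol-3-yl.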